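Removing the ring methyl from compound 1: expected cytotoxicity

The compounds below may be only part of what the source reports. "The series", "measured", "known", "first", "only" and "open" are said of these compounds alone.

Measured so far:
compound 1 `Cc1cccc(Cl)c1CN1CCc2cc(-c3c(C)nc(C)c([C@H](OC(C)(C)C)C(=O)O)c3N3CCC(C)(C)CC3)ccc2C1` — 22500 nM
compound 2 `Cc1nc(C)c([C@H](OC(C)(C)C)C(=O)O)c(N2CCC(C)(C)CC2)c1-c1ccc2c(c1)CCN(Cc1cccc(F)c1F)C2` — >= 24000 nM

For the measured compounds named here, in a toxicity assay on MT2 cells (Homo sapiens) for cytotoxicity (on this read-out lower numbers stand for higher toxicity in this test and higher numbers for lower toxicity in this test), compound 1 gives 22500 nM, the only plain number in the set. Compound 2 gives >= 24000 nM, which is a limit of this assay and not a number; (the limit of >= 24000 nM in this assay, at which 1 of the 2 values shown sits). Going by the values given here, the one measured step, an at least 1.0-fold higher number from compound 1 to compound 2 (0.02 log units; that floor lies within the scatter), concerns a different position and lies within the scatter, so no measured step bears on the change at hand.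

Compound 3 `Cc1cccc(Cl)c1CN1CCc2cc(-c3cnc(C)c([C@H](OC(C)(C)C)C(=O)O)c3N3CCC(C)(C)CC3)ccc2C1` differs from compound 1 by hydrogen in place of methyl on an aromatic carbon. Among the compounds with values here, with no step to draw on, a change of no size beyond the scatter is expected, a 1.0-fold lower number from compound 1 to compound 3 (0.01 log units; within the scatter). Compound 3 is estimated at 22000 nM in this assay, within 10000 nM to 45000 nM.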

Compound 3, half-maximal cytotoxic concentration: 19500 nM
The estimate for compound 3 lay 1.1-fold (0.05 log units) above the measured number, and the stated range covers the measured number.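

In this assay, hydrogen in place of methyl on this aromatic carbon, next to the ring nitrogen, gives a 1.2-fold lower number from compound 1 to compound 3 (0.06 log units; within the scatter), so this methyl can go without a change beyond the scatter. Compound 2 remains a limit of the assay and not a number, so the ceiling of the read-out lies close to these values: the limit of >= 24000 nM in this assay, at which 1 of the 3 values shown sits.

Going by these compounds, whether an ethyl, a methoxy or an amine at this carbon would shift the read-out stays open. So does whether removing the methyl gives the same result with the 2,3-difluorophenyl of compound 2.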